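The source may report more compounds than this note shows. Statements on the series, on what has been measured and on what is new or still open speak of the compounds shown alone.

Compound 1: `CCN(CC)C(=O)c1cc2cc(C)ccc2n1Cc1ccc(O)cc1` — > 10000 nM
Compound 2: `CC(=O)N(Cc1ccccc1)c1cc(C)cc(C)c1` — 276 nM

In an assay on membranes from HEK293 cells for displacement of a labelled ligand from Translocator protein (Homo sapiens), read by scintillation counting, with a stated time of 90 min (on this read-out lower numbers stand for stronger inhibition and higher numbers for weaker inhibition), compound 1 gives > 10000 nM, which is a limit of the assay rather than a number. In this assay, among the measured compounds shown here, compound 2 gives 276 nM, the only number measured here. Compound 3 is `CC(=O)N(Cc1ccc(OCCF)cc1)c1cc(C)cc(C)c1`; it differs from compound 2 by 2-fluoroethoxy in place of hydrogen on an aromatic carbon. For the measured compounds named here, no measured pair shows what such a change does in this assay, so only a modest step toward stronger binding is expected. For compound 3 an inhibition constant of 100 nM is estimated, within 30 nM to 600 nM. That estimate means an expected step of a 2.8-fold lower number from compound 2 to compound 3 (0.44 log units; beyond the scatter).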

Compound 3, inhibition constant: 275 nM
For compound 3 the middle estimate is 2.8-fold (0.44 log units) below the measured one; measured number inside the range.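

In this assay the step of a 1.0-fold lower number from compound 2 to compound 3 (0.00 log units; within the scatter) shows that 2-fluoroethoxy can replace hydrogen at this place on the six-membered aromatic ring, para to a large group, without a change that can be told from scatter. Among the compounds shown here, this is the first measured pair to show that the position accepts such a chain. Nothing given here accounts for this result.

From the compounds shown here alone, whether a longer chain, an amine or a carboxylic acid at the same place would bind alike remains open. One pair also cannot show whether this change would give the same result on another core, such as that of compound 1.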